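The source may hold more compounds than are shown below. What is called first, only, known or untested is meant among the compounds shown, and "the series" means these compounds.

Working notes on the series. The shared core is that of compound 1 `COc1cc(Cl)cc(-c2nn(-c3cccc(NC(=O)c4ccc(Cl)c(Cl)c4)c3)cc2-c2ccncc2)c1`, an amide bearing a 3,4-dichlorophenyl on the carbonyl carbon; in a functional assay on OVCAR-5 cells (Homo sapiens) for inhibition, read by sulforhodamine B assay, with a stated time of 48 h, tested at 10 uM (on this read-out higher numbers stand for a weaker effect at the one concentration tested and lower numbers for a stronger effect), compound 1 gives 79.2%. Compound 2 `O=C(Nc1cccc(-n2cc(-c3ccncc3)c(-c3cc(O)cc(Cl)c3)n2)c1)Nc1ccc(Cl)c(Cl)c1` is a urea with a 3,4-dichlorophenyl and a hydroxy where the others carry a methoxy; in this assay compound 2 gives -2.26%. Compound 3 `COc1cc(Cl)cc(-c2nn(-c3cccc(NC(=O)Nc4ccc(Cl)c(C(F)(F)F)c4)c3)cc2-c2ccncc2)c1` is the methoxy urea with a 4-chloro-3-(trifluoromethyl)phenyl; in this assay compound 3 gives 19.2%, the second highest of the three numbers, beyond the scatter from both compound 2 and compound 1. Going by the values given here, the only measured step is a number 60 percentage points lower from compound 1 to compound 3 (beyond the scatter), and it carries two changes at once, amide to urea and 3,4-dichlorophenyl to (4-chloro-3-(trifluoromethyl)phenyl)amino, so it cannot be split. Compound 4 `COc1cc(Cl)cc(-c2nn(-c3cccc(NC(=O)Nc4ccc(Cl)c(Cl)c4)c3)cc2-c2ccncc2)c1` is the methoxy urea with the 3,4-dichlorophenyl; the change from compound 3 is chloro in place of trifluoromethyl on an aromatic carbon. Among the compounds with values here, no measured step isolates this exchange. Compound 4 differs from compound 2 only in methoxy against hydroxy, and compound 2 sits lower than compound 3, so the two ureas bracket the expectation. Compound 4 is expected to land close to or somewhat below compound 3, a step of a number 9.2 percentage points lower from compound 3 to compound 4 (within the scatter) that may fall within the scatter. The estimate for compound 4 is 10%, in a range from -10% to 35%.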

Compound 4, a percentage reported as activity, at one concentration (the size of the read-out at that concentration, not a potency): 37.8%
Beside the measured number, compound 4's estimate is 27.8 percentage points below it; measured number above the stated range.
By their numbers in this assay, from the lowest: compound 2; then compound 3; then compound 4; then compound 1.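

On the aryl ring of the methoxy urea, the exchange on this aromatic carbon, ortho to a chloro group, is now measured alone: chloro in place of trifluoromethyl gives a number 18.6 percentage points higher from compound 3 to compound 4 (beyond the scatter) in this assay, so trifluoromethyl is the form with the stronger effect at the one concentration tested. This also separates the two changes that were combined in the earlier step, since with 3,4-dichlorophenyl held constant, the amide and urea link alone gives a number 41.4 percentage points lower from compound 1 to compound 4 (beyond the scatter), a larger step than the aryl exchange, and the urea is the form with the stronger effect. On the other side of the core, the oxygen substituent proves to matter as much as the link: methyl in place of hydrogen gives a number 40.1 percentage points higher from compound 2 to compound 4 (beyond the scatter), so in this urea pair the hydroxy compound has the stronger effect.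

Nothing available bears on the reason for any of these steps. Still open, going by these compounds, is whether the hydroxy and the trifluoromethyl changes add up in one urea, and how a nitrile or a carboxylic acid on the same aromatic carbon would compare with chloro and trifluoromethyl.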